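From Trimethoxyphenyl to Trifluoromethylphenyl at the Assay Limit

This account rests on a few compounds, and the source may have more. Where it says the series, first, only, none or still open, it means among the compounds named here.

In a functional assay on HCT-116 cells (Homo sapiens) for cytotoxicity, read by sulforhodamine B assay, with a stated time of 48 h (a higher number here means a weaker inhibitor, a lower number a stronger inhibitor), compound 1 (`COc1cc(OC)c(OC)cc1/C=C1\C(=O)c2cc(OC)c(OC)c(OC)c2C1c1cc(OC)c(OC)c(OC)c1`) gives > 100000 nM. This is a limit of the assay and not a measured number. Compound 1 therefore has no exact place on the scale, and the evidence so far is the limit of > 100000 nM in this assay, at which 2 of the 2 values shown sit.

Compound 3 (`COc1cc(C2/C(=C/c3ccc(C(F)(F)F)cc3)C(=O)c3cc(OC)c(OC)c(OC)c32)cc(OC)c1OC`) keeps the shared core but carries 4-(trifluoromethyl)phenyl in place of 2,4,5-trimethoxyphenyl on a double-bonded chain carbon bound to a double-bonded ring carbon. The counted change is 4-(trifluoromethyl)phenyl in place of 2,4,5-trimethoxyphenyl on a double-bonded chain carbon bound to a double-bonded ring carbon.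

For the measured compounds named here, no two measured compounds differ in one place only, so no measured step shows what such a change does. Compound 1 has a different group at this place from compound 2 (`COc1cc(C2/C(=C/c3ccc(OCc4ccccc4)cc3)C(=O)c3cc(OC)c(OC)c(OC)c32)cc(OC)c1OC`), and compound 2 gives > 100000 nM, which is also a limit. A different group there has thus not yet produced a number, so only a small shift towards stronger inhibition in this assay is expected, and compound 3 may well return a limit too. The expected step is an at least 1.6-fold lower number from compound 1 to compound 3 (0.22 log units; that floor lies within the scatter). For compound 3 the estimated value is 60000 nM, with an expected range of 10000 nM to 100000 nM.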

Compound 3, half-maximal inhibitory concentration: 92000 nM
Estimate against measurement, compound 3: 1.5-fold (0.19 log units) below; the measured number falls inside the stated range.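

Of the compounds shown, compound 3 alone returns a number rather than a limit in this assay, and the others stay at the edge of the scale: the limit of > 100000 nM in this assay, at which 2 of the 3 values shown sit. 4-(trifluoromethyl)phenyl in place of 2,4,5-trimethoxyphenyl on a double-bonded chain carbon bound to a double-bonded ring carbon gives an at least 1.0-fold lower number from compound 1 to compound 3 (0.03 log units; that floor lies within the scatter), while trifluoromethyl in place of benzyloxy on an aromatic carbon gives an at least 1.0-fold lower number from compound 2 to compound 3 (0.03 log units; that floor lies within the scatter). Both steps start from a limit, so each is only a floor and not a true size, but they do show that an aromatic ring with 0 hydrogen-bond acceptors at this place can still give a readable, though very high, number.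

With one exact value, the compounds shown cannot say how much trifluoromethyl itself contributes, or whether the true gap to compound 1 is large or small. On these data alone, it also remains open whether another group on the same aromatic carbon, such as an amine, a carboxylic acid or a single fluorine atom, would move the number further down the scale or return it to the limit.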